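The source may hold more compounds than are shown below. What is called first, only, known or untested is meant among the compounds shown, and "the series" means these compounds.

Notes on the series. Compound 1 `CC1=C(C(=O)OC2CCCCC2)C(c2cccc(C#N)c2)C2=C(CC(C)(C)CC2=O)N1` in an assay on HEK293 cells for inhibition of neurogenic locus notch homolog protein 1 (Homo sapiens), read by a luciferase reporter and resazurin assay, with a stated time of 16 h (a higher number here means a weaker inhibitor, a lower number a stronger inhibitor), gives 43200 nM. Compound 2 `CC1=C(C(=O)OCC2CCN(C(=O)OC(C)(C)C)CC2)[C@@H](c2cccc(Br)c2)C2=C(CC(C)(C)CC2=O)N1` in this assay gives 2590 nM. Compound 3 `CC1=C(C(=O)OCC2CCN(C(=O)OC(C)(C)C)CC2)C(c2cccc([N+](=O)[O-])c2)C2=C(CC(C)(C)CC2=O)N1` in this assay reaches only a limit, > 10000 nM; this is the limit of > 10000 nM in this assay, at which 1 of the 3 values shown sits, so compound 3 is known only as weaker than that cut-off and no finished number stands for it. Compound 4 `CC1=C(C(=O)OCC2CCN(C(=O)OC(C)(C)C)CC2)C(c2ccc3c(c2)OCCO3)C2=C(CC(C)(C)CC2=O)N1` carries 2,3-dihydro-1,4-benzodioxin-6-yl in place of 3-nitrophenyl on a saturated ring carbon. No measured step between the shown compounds covers this change, and the two values of compound 2 and compound 1 differ in more than one place, so no direction can be read from them. The step of an at least 1.1-fold lower number from compound 3 to compound 4 (0.04 log units; that floor lies within the scatter) is expected to remain small, not clearly beyond the scatter. Compound 4 in this assay is therefore estimated at 9000 nM, between 2500 nM and 30000 nM.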

Compound 4, half-maximal inhibitory concentration: 1520 nM
For compound 4 the middle estimate is 5.9-fold (0.77 log units) above the measured one, and the stated range ends above it.
By their numbers in this assay, from the lowest: compounds 4 and 2 (each within the scatter of the next); then compound 1.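

In this assay, within the data shown here, the group on the saturated ring carbon now shows a readable effect for the first time: 2,3-dihydro-1,4-benzodioxin-6-yl in place of 3-nitrophenyl gives an at least 6.5-fold lower number from compound 3 to compound 4 (0.81 log units; beyond the scatter). This step is only a floor, because compound 3 stands at a limit: the limit of > 10000 nM in this assay, at which 1 of the 4 values shown sits.

On these data alone, it remains open whether the six-membered non-aromatic ring of the entering group is needed, or whether an open dimethoxyphenyl would read the same. As far as these compounds go, how a phenyl carrying an amine or a carboxylic acid would read on this carbon also remains open.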